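A few compounds are considered here, and "the series" means these few. Any claim that something is new, unique, unknown or untested is made for them only; others in the source may bear on it.

Measured so far:
Compound 1 `Clc1ccc(-n2cc(COc3cccc4cnc(Nc5cccc(Cl)c5)nc34)nn2)cc1` gives > 25000 nM in an ADME assay on cells (Fibroblast, Homo sapiens) for cytotoxicity, read by cell counting, with a stated time of 48 h; on this read-out higher numbers stand for weaker inhibition and lower numbers for stronger inhibition; this is a limit of the assay, not a number.
Compound 2 `COc1ccccc1-n1cc(COc2cccc3cnc(Nc4cccc(Cl)c4)nc23)nn1` gives > 25000 nM in this assay; this too is a limit.
Compound 3 `Clc1cccc(Nc2ncc3cccc(OCc4cn(Cc5c(Cl)cccc5Cl)nn4)c3n2)c1` gives 14000 nM in this assay.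

Going by the values given here, compound 3 thus holds the only number among the three results, the other two sitting at the limit of > 25000 nM in this assay, at which 2 of the 3 values shown sit. The new compound 4 `Clc1cccc(Nc2ncc3cccc(OCc4cn(-c5cc(Cl)cc(Cl)c5)nn4)c3n2)c1` has not yet been measured. It differs from compound 3 in one place: 3,5-dichlorophenyl in place of 2,6-dichlorobenzyl on an aromatic nitrogen. The group on the aromatic nitrogen of the five-membered ring changes from a benzyl type to a phenyl type, which is the reverse of what the measured steps show. Those steps, an at least 1.7-fold lower number from compound 1 to compound 3 (0.25 log units; that floor lies within the scatter) and an at least 1.7-fold lower number from compound 2 to compound 3 (0.25 log units; that floor lies within the scatter), both run from a phenyl-type group to the 2,6-dichlorobenzyl group and both give a lower number, though only by a floor that lies within the scatter. Turning back from 2,6-dichlorobenzyl to 3,5-dichlorophenyl is therefore expected to raise the number for compound 4 in this assay, plausibly back to the limit where compound 1 and compound 2 sit, so the estimated step is a 1.8-fold higher number from compound 3 to compound 4 (0.25 log units; within the scatter). For compound 4 the expected value is 25000 nM, estimated to lie between 10000 nM and 60000 nM.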

Compound 4, half-maximal inhibitory concentration: 8000 nM
Beside the measured number, compound 4's estimate is 3.1-fold (0.49 log units) above it, outside the stated range (below it).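

Compound 4 shows that a phenyl-type group on the aromatic nitrogen does not by itself hold a compound at the high end of this assay: with 3,5-dichlorophenyl there, the readings are an at least 3.1-fold lower number from compound 2 to compound 4 (0.49 log units; beyond the scatter) and an at least 3.1-fold lower number from compound 1 to compound 4 (0.49 log units; beyond the scatter). Both of these steps start from a limit of the assay and not from a number, so each gives only a floor: the limit of > 25000 nM in this assay, at which 2 of the 4 values shown sit. Set against the benzyl-type group, the change reads a 1.8-fold lower number from compound 3 to compound 4 (0.24 log units; within the scatter), so compound 3 and compound 4 cannot be told apart here, and what separates compound 4 from compound 1 and compound 2 is the choice of group on the phenyl ring, not a switch from benzyl to phenyl.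

The chlorine pattern and the carbon link still cannot be pulled apart: that would take a 2,6-dichlorophenyl group and a 3,5-dichlorobenzyl group on the same nitrogen. From the compounds shown here alone, it also stays open how this read-out would respond to an amine or a carboxylic acid on that ring, or to a longer chain between the ring and the nitrogen.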